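A Methoxy Group Enters the Phenyl Ring of Compound 1

This account rests on a few compounds, and the source may have more. Where it says the series, first, only, none or still open, it means among the compounds named here.

Measured compounds:
Compound 1, `c1ccc(-c2ccc3c(NCCCNCc4ccco4)ccnc3c2)cc1`, gives 5920 nM in an ADME assay on HepG2 cells (Homo sapiens) for cytotoxicity, read by luminescence, CellTiter-Glo and ATP content, with a stated time of 72 h; on this read-out higher numbers stand for an effect only at larger amounts of compound and lower numbers for an effect already at smaller amounts.
Compound 2, `COc1cccc(CNCCCNc2ccnc3cc(-c4ccc(C(F)(F)F)cc4)ccc23)c1O`, gives 2210 nM in this assay.
Compound 3, `COc1cccc(CNCCCNc2ccnc3cc(-c4ccccc4)ccc23)c1O`, gives 3210 nM in this assay.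

Among these three numbers compound 1 stands highest. Its nearest neighbour is compound 3, reached by a 1.8-fold lower number from compound 1 to compound 3 (0.27 log units; within the scatter). Compound 2 lies furthest from compound 1; its value is lower, and that gap is beyond the scatter.

Compound 4, `COc1ccc(-c2ccc3c(NCCCNCc4ccco4)ccnc3c2)cc1`, has not been measured. It differs from compound 1 by methoxy in place of hydrogen on an aromatic carbon. Within the data shown here, two measured steps bear on this. The closest is the exchange of a group on the same phenyl ring, where a 1.5-fold higher number from compound 2 to compound 3 (0.16 log units; within the scatter). The other is a change at the far end of the chain, where a 1.8-fold lower number from compound 1 to compound 3 (0.27 log units; within the scatter). Both stayed within the scatter, so for compound 4 no step beyond the scatter is expected in this assay, which is what a 1.2-fold lower number from compound 1 to compound 4 (0.07 log units; within the scatter) means. Compound 4 is therefore estimated at 5000 nM, with a range from 2500 nM to 11000 nM.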

Compound 4, half-maximal effective concentration: 6000 nM
Compound 4: middle estimate off by 1.2-fold (0.08 log units), on the low side, within the range that was stated.
By their numbers in this assay, from the lowest: compounds 2, 3, 1 and 4 (each within the scatter of the next, the first and the last beyond it).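

In this assay, methoxy on the phenyl ring, para to a large group, gives a 1.0-fold higher number from compound 1 to compound 4 (0.01 log units; within the scatter), so this ring carbon takes a group with an oxygen atom without a step beyond the scatter when furan-2-yl is at the end of the chain. The one earlier step on this ring, a 1.5-fold higher number from compound 2 to compound 3 (0.16 log units; within the scatter), involved trifluoromethyl and had 2-hydroxy-3-methoxyphenyl at the chain end, so both exchanges shown on this ring, with two different chain ends, now lie within the scatter. Nothing shown gives any explanation for this result.

On these data alone, whether an amine or a carboxylic acid at this place on the phenyl ring would give a step beyond the scatter remains open. Also open, as far as these compounds go, is whether methoxy here would give a similar result in compound 3, with its 2-hydroxy-3-methoxyphenyl group.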